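Adding a methoxy to compound 3 in a cell test

The compounds below may be only part of what the source reports. "The series", "measured", "known", "first", "only" and "open" are said of these compounds alone.

Measured values in an ADME assay on THP-1 cells (Homo sapiens) for cytotoxicity, read by flow cytometry and propidium iodide staining, with a stated time of 72 h (on this read-out lower numbers stand for stronger inhibition and higher numbers for weaker inhibition), are these:
- compound 1 `COc1ccccc1-c1oc2ccc(N)cc2c(=O)c1O` (value 102000 nM)
- compound 2 `COc1ccccc1-c1oc2ccc(NC(C)=O)cc2c(=O)c1OC` (value 108000 nM)
- compound 3 `COc1c(-c2ccccc2)oc2ccc(N)cc2c1=O` (value 74000 nM)

Compound 3 stands within the usual scatter of both other compounds, so these three numbers cannot be told apart. Repeating a measurement of this kind could shuffle them without any real difference between the compounds.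

Going from compound 3 to compound 4 `COc1ccccc1-c1oc2ccc(N)cc2c(=O)c1OC` makes one structural change: methoxy in place of hydrogen on an aromatic carbon (methoxy in place of hydrogen on an aromatic carbon of a six-membered aromatic ring of carbon only, ortho to a large group).

Within the data shown here, no two measured compounds differ in just one place, so the data hold no direct example of what this change does. Among the measured compounds shown here, the only guide is the narrow spread of the measured numbers, and no single change can be read from it. A shift beyond the scatter is therefore not expected, and no direction is clearly favoured. The expected size is a 1.2-fold higher number from compound 3 to compound 4 (0.09 log units; within the scatter) and this estimate stays within the scatter. Compound 4 is estimated at 90000 nM (expected range 50000 nM to 150000 nM).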

Compound 4, half-maximal inhibitory concentration: 116000 nM
Compound 4: middle estimate off by 1.3-fold (0.11 log units), on the low side, within the range that was stated.
By their numbers in this assay, from the lowest: compounds 3, 1, 2 and 4 (each within the scatter of the next).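

In this assay, among these compounds, methoxy in place of hydrogen on an aromatic carbon, ortho to a large group, gives a 1.6-fold higher number from compound 3 to compound 4 (0.20 log units; within the scatter) and so provides the first direct example of this change, with no effect that can be told from the scatter. Compound 4 also links the other two compounds through single changes, since hydrogen in place of acetyl on a nitrogen on an aromatic ring gives a 1.1-fold higher number from compound 2 to compound 4 (0.03 log units; within the scatter) while methyl in place of hydrogen on an oxygen on an aromatic ring gives a 1.1-fold higher number from compound 1 to compound 4 (0.06 log units; within the scatter) and neither step can be told from the scatter either. Nothing measured alongside these compounds speaks to the reason for these results.

All three single changes therefore leave the number in the same narrow band, and they cover only a few small groups at these places. From the compounds shown here alone, whether a larger change could move the number beyond the scatter remains open, for example a longer chain such as butoxy in place of the methoxy, or a carboxylic acid in place of the amine.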